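The source may hold more compounds than are shown below. What is called first, only, known or untested is meant among the compounds shown, and "the series" means these compounds.

Compound 1, with the structure `COC(=O)[C@@]1(C)CCC=C2[C@@H]1CC[C@@H](C)[C@]2(C)Cc1c[nH]c2c(C)cccc12`, gives 26000 nM in a functional assay on WiDr cells (Homo sapiens) for inhibition, read by sulforhodamine B assay, with a stated time of 48 h; on this read-out lower numbers stand for stronger inhibition of growth and higher numbers for weaker inhibition of growth. Compound 2, with the structure `COC(=O)[C@@]1(C)CCC=C2[C@@H]1CC[C@@H](C)[C@]2(C)Cc1c(C)[nH]c2c(C)cccc12`, differs from it by one change, (methyl in place of hydrogen on an aromatic carbon), and in this assay compound 2 gives 21000 nM; the step is a 1.2-fold lower number from compound 1 to compound 2 (0.09 log units; within the scatter).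

Compound 3, with the structure `COC(=O)[C@@]1(C)CC[C@@H]2C3=C1CC[C@@H](C)[C@]3(C)C[C@@H]1c3ccccc3N[C@H]21`, is built on a different core; the difference between the two cores is not broken down here. In this assay compound 3 gives 50000 nM.

Compound 4, with the structure `COC(=O)[C@@]1(C)CC[C@@H]2C3=C1CC[C@@H](C)[C@]3(C)C[C@@H]1c3cc(C)ccc3N[C@H]21`, has not been measured. It differs from compound 3 by methyl in place of hydrogen on an aromatic carbon. Going by the values given here, this is the same kind of change as the one from compound 1 to compound 2, not the same: the earlier methyl sits on a five-membered aromatic ring with one nitrogen, next to the ring nitrogen and next to the ring atom that bears a large group, whereas the new one sits on a six-membered aromatic ring of carbon only, part of a fused or bridged system of five rings, meta to a fused ring and para to a fused ring.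

Because a 1.2-fold lower number from compound 1 to compound 2 (0.09 log units; within the scatter) stayed small, the expected step is a 1.1-fold lower number from compound 3 to compound 4 (0.05 log units; within the scatter), which rests on that single earlier step. Compound 4 is estimated to give about 45000 nM in this assay, most likely between 20000 nM and 100000 nM.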

Compound 4, concentration for 50% growth inhibition: 32000 nM
The estimate for compound 4 lay 1.4-fold (0.15 log units) above the measured number, and the stated range covers the measured number.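

Putting methyl in place of hydrogen on an aromatic carbon of the core of compound 3 gives a 1.6-fold lower number from compound 3 to compound 4 (0.19 log units; within the scatter) in this assay. So far, the change behaves alike on both cores: the same change on two cores in this assay, a 1.2-fold lower number (0.09 log units; within the scatter) from compound 1 to compound 2 and a 1.6-fold lower number (0.19 log units; within the scatter) from compound 3 to compound 4, 1.3-fold (0.10 log units) apart, within the scatter of two such steps. Each step lies within the scatter, however, so neither shows a real effect of the methyl on growth inhibition, and two pairs, with the methyl on a different kind of ring in each, make no rule for other cores.

The compounds shown carry only hydrogen or methyl at these two places, leaving open whether an ethyl group, a methoxy group, chlorine or an amine would move the number beyond the scatter on either core. They also leave open how methyl would act elsewhere on the six-membered aromatic ring.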